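8-Phenyl Xanthines: From Para-Nitro to Para-Butoxy

The source may report more compounds than this note shows. Statements on the series, on what has been measured and on what is new or still open speak of the compounds shown alone.

Compound 2 `Cn1c(=O)c2nc(-c3ccc([N+](=O)[O-])cc3)[nH]c2n(C)c1=O` gives 8 nM in an assay for binding affinity to adenosine receptor A1 (Bos taurus) (on this read-out lower numbers stand for stronger inhibition and higher numbers for weaker inhibition), the highest of the three numbers shown; compound 1 `CCCn1c(=O)c2nc(-c3ccccc3N)[nH]c2n(CCC)c1=O` gives 0.75 nM and compound 3 `CCCn1c(=O)c2nc(-c3ccc(Cl)cc3N)[nH]c2n(CCC)c1=O` gives 0.05 nM. Going by the values given here, the one measured step, a 15-fold lower number from compound 1 to compound 3 (1.18 log units; beyond the scatter), concerns a chloro group on a different ring position and does not touch the para substituent. Compound 4 `CCCCOc1ccc(-c2nc3c(=O)n(C)c(=O)n(C)c3[nH]2)cc1` differs from compound 2 by butoxy in place of nitro on an aromatic carbon. Among the compounds with values here, no measured pair shows a butoxy entering for a nitro, so nothing measured bears directly on this change, and the expectation is a small step, if any, beyond the scatter. Compound 4 is therefore estimated at 15 nM, with a range from 3 nM to 75 nM, meaning an expected 1.9-fold higher number from compound 2 to compound 4 (0.27 log units; within the scatter).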

Compound 4, half-maximal inhibitory concentration: 4 nM
Compound 4: middle estimate off by 3.8-fold (0.57 log units), on the high side; low and high end bracket the measured number.
By their numbers in this assay, from the lowest: compound 3; then compound 1; then compounds 4 and 2 (each within the scatter of the next).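

In this assay, butoxy in place of nitro gives a 2.0-fold lower number from compound 2 to compound 4 (0.30 log units; within the scatter), so the two compounds cannot be told apart. Going by these compounds alone, this place on the ring therefore tolerates the larger butoxy group, with its four-carbon chain, as well as it does nitro, something the earlier compounds, whose one step involved chloro, could not show. Nothing available explains why the two read alike.

Going by these compounds, whether an amine, a carboxylic acid or a longer chain such as hexyloxy would fare the same here remains open. So does whether butoxy would hold up on the core of compound 1.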